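Aryl ketone variation across a shared stilbene-chalcone core

The compounds below may be only part of what the source reports. "The series", "measured", "known", "first", "only" and "open" are said of these compounds alone.

Measured so far in a functional assay on B16-F10 cells (Mus musculus) for antiproliferative activity, read by MTT assay, with a stated time of 48 h; on this read-out lower numbers stand for stronger inhibition and higher numbers for weaker inhibition:
compound 1, `COc1ccc(/C=C/c2cc(OC)cc(OC)c2/C=C/C(=O)c2cccc(Br)c2)cc1`, gives 5.1 ug/mL.
compound 2, `COc1ccc(/C=C/c2cc(OC)cc(OC)c2/C=C/C(=O)c2cccc(Cl)c2)cc1`, gives 3.3 ug/mL.
compound 3, `COc1ccc(/C=C/c2cc(OC)cc(OC)c2/C=C/C(=O)c2ccc(C)c(C)c2)cc1`, gives 1.4 ug/mL.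

Compound 3 holds the lowest number of the three: a 3.6-fold lower number from compound 1 to compound 3 (0.56 log units; beyond the scatter) and a 2.4-fold lower number from compound 2 to compound 3 (0.37 log units; beyond the scatter), both beyond the scatter, while a 1.5-fold lower number from compound 1 to compound 2 (0.19 log units; within the scatter) stays within it. Compound 4, `COc1ccc(/C=C/c2cc(OC)cc(OC)c2/C=C/C(=O)c2cccc(OC)c2)cc1`, differs from compound 3 only at the carbonyl carbon: 3-methoxyphenyl in place of 3,4-dimethylphenyl on a carbonyl carbon. For the measured compounds named here, no measured step exchanges the dimethyl for a methoxy pattern on this ring; the two steps that touch the ring, from compound 1 to compound 3 and from compound 2 to compound 3, show that altering its substitution shifts the number modestly. A modest shift towards a higher number is expected for compound 4, a 1.9-fold higher number from compound 3 to compound 4 (0.27 log units; within the scatter). Compound 4 is estimated at 2.6 ug/mL, with a range from 1 ug/mL to 6.5 ug/mL.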

Compound 4, half-maximal inhibitory concentration: 4.3 ug/mL
Estimate against measurement, compound 4: 1.7-fold (0.22 log units) below; measured number inside the range.
By their numbers in this assay, from the lowest: compound 3; then compounds 2, 4 and 1 (each within the scatter of the next).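

With a 3.1-fold higher number from compound 3 to compound 4 (0.49 log units; beyond the scatter) the 3-methoxyphenyl group does not hold the level of the 3,4-dimethylphenyl group on the carbonyl carbon. With a 1.3-fold higher number from compound 2 to compound 4 (0.11 log units; within the scatter) and a 1.2-fold lower number from compound 1 to compound 4 (0.07 log units; within the scatter) both steps stay within the scatter, so methoxy cannot be told from chloro or bromo on that aromatic carbon, and compound 3 alone stands apart among the four. Nothing available here bears on the reason for this separation.

Open, as far as these compounds go, is whether a single methyl on this ring keeps the level of compound 3 or both methyl groups are needed. From the compounds shown here alone, how an amine or a carboxylic acid on the ring would read also stays open.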